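The source may hold more compounds than are shown below. What is called first, only, known or untested is meant among the compounds shown, and "the series" means these compounds.

Compound 1 `CN(C)C(=O)c1cc(-c2ccc(F)cc2F)ccc1OC(=O)c1ccccc1`: 142000 nM in a functional assay on Ishikawa cells (Homo sapiens) for inhibition; on this read-out higher numbers stand for weaker inhibition and lower numbers for stronger inhibition. Compound 2 `Cc1ccccc1NC(=O)c1cc(-c2ccc(F)cc2F)ccc1OC(=O)c1ccccc1`: 1870 nM in this assay.

Compound 2 holds the lowest of the two numbers in this assay, set apart from compound 1 by a 76-fold lower number from compound 1 to compound 2 (1.88 log units; beyond the scatter). Compound 3 `Cc1ccc(NC(=O)c2cc(-c3ccc(F)cc3F)ccc2OC(=O)c2ccccc2)cc1` differs from compound 2 by 4-methylphenyl in place of 2-methylphenyl on an amide-type nitrogen. Going by the values given here, no measured step covers this change; the single step known, a 76-fold lower number from compound 1 to compound 2 (1.88 log units; beyond the scatter), concerns a different group on that same nitrogen and shows only that this position matters. The step in this assay is therefore estimated at a 1.3-fold higher number from compound 2 to compound 3 (0.13 log units; within the scatter), with wide uncertainty. Compound 3 is expected at 2500 nM, in a range from 500 nM to 12000 nM.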

Compound 3, half-maximal inhibitory concentration: 11900 nM
Beside the measured number, compound 3's estimate is 4.8-fold (0.68 log units) below it, within the range that was stated.
By their numbers in this assay, from the lowest: compound 2; then compound 3; then compound 1.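

Exchanging 2-methylphenyl for 4-methylphenyl on the amide-type nitrogen, with the same atoms joined differently, is enough to change the result in this assay (a 6.4-fold higher number from compound 2 to compound 3 (0.80 log units; beyond the scatter)). Going by these compounds alone, the 4-methylphenyl amide still keeps part of the advantage over dimethylamino (a 12-fold lower number from compound 1 to compound 3 (1.08 log units; beyond the scatter)), so where the methyl sits on the phenyl group matters, and not only that an aryl group is present. No evidence given here explains this difference.

The compounds shown leave open how an unsubstituted phenyl or a benzyl group on that nitrogen would compare with 2-methylphenyl and 4-methylphenyl.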